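Stretching the Propyl Chain of Compound 1

The source may hold more compounds than are shown below. What is called first, only, known or untested is meant among the compounds shown, and "the series" means these compounds.

- compound 1 `CCCc1ccc(-c2c(C)[nH]c(=O)n2C2CCCCC2)cc1` gives 13900 nM
- compound 2 `Cc1[nH]c(=O)n(C2CCCCC2)c1-c1ccc(C2CCCCC2)cc1` gives 28900 nM

In a functional assay on brain (Rattus norvegicus, strain Wistar) for inhibition (a higher number here means a weaker inhibitor, a lower number a stronger inhibitor), compound 1 holds the lower of the two numbers, which makes it the stronger inhibitor of the pair. Compound 3 `CCCCCCCCCCCCCCc1ccc(-c2c(C)[nH]c(=O)n2C2CCCCC2)cc1` differs from compound 1 at its propyl chain: undecyl in place of hydrogen on a saturated chain carbon, three bonds along the chain from an aromatic carbon. Going by the values given here, only one measured step bears on this change, the swap of propyl for cyclohexyl on an aromatic carbon, and it is modest but beyond the scatter: a 2.1-fold higher number from compound 1 to compound 2 (0.32 log units; beyond the scatter). Resting on that single step, a modest move towards a weaker number is expected in this assay, with wide uncertainty, since no chain this long has been measured. The expected step is a 2.2-fold higher number from compound 1 to compound 3 (0.33 log units; beyond the scatter). For compound 3 the estimated value is 30000 nM, within a range of 6000 nM to 120000 nM.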

Compound 3, half-maximal inhibitory concentration: > 100000 nM
Compound 3 ended at the assay's limit (the forecaster's own chance of this, stated with the estimate: 25%); middle value at least 3.3-fold (0.52 log units) away from the limit.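

Going by these compounds alone, compound 1 had so far been changed only by swapping its propyl group for cyclohexyl, which gave a 2.1-fold higher number from compound 1 to compound 2 (0.32 log units; beyond the scatter). Lengthening the chain itself is now seen to weaken inhibition in this assay as well, with undecyl on the saturated chain carbon giving an at least 7.1-fold higher number from compound 1 to compound 3 (0.85 log units; beyond the scatter), so this long chain is not tolerated at this place without a clear loss. Compound 3 gives > 100000 nM, which is a limit of the assay and not a number, and it is the only such case among these compounds: the limit of > 100000 nM in this assay, at which 1 of the 3 values shown sits.

The compounds shown leave open how the number changes between propyl and this long chain, a question that a pentyl or an octyl chain would address. Also open, going by these compounds, is whether a chain ending in an amine or a carboxylic acid would behave like the plain carbon chain.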